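Benzofuranyl pyrazoline amides: Vero cell cytotoxicity and a methoxy question

The source may report more compounds than this note shows. Statements on the series, on what has been measured and on what is new or still open speak of the compounds shown alone.

The three measured compounds share one core and differ only in the aryl group on the saturated ring carbon of the pyrazoline. Compound 1 `CCn1cc(C(=O)N2N=C(c3cc4ccccc4o3)CC2c2ccccc2O)c(=O)c2ccc(C)nc21` carries a 2-hydroxyphenyl group there, compound 2 `CCn1cc(C(=O)N2N=C(c3cc4ccccc4o3)CC2c2ccc(OC)cc2O)c(=O)c2ccc(C)nc21` a 2-hydroxy-4-methoxyphenyl group, and compound 3 `CCn1cc(C(=O)N2N=C(c3cc4ccccc4o3)CC2c2ccc(OC)cc2)c(=O)c2ccc(C)nc21` a 4-methoxyphenyl group. Compound 4 `CCn1cc(C(=O)N2N=C(c3cc4ccccc4o3)CC2c2ccccc2)c(=O)c2ccc(C)nc21` carries a plain phenyl group.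

In an ADME assay on Vero cells (Chlorocebus sabaeus) for cytotoxicity, read by MTT assay, with a stated time of 72 h (on this read-out lower numbers stand for stronger inhibition and higher numbers for weaker inhibition), compound 1 gives only a limit, > 157000 nM. Compound 2 likewise reaches only a limit in this assay, > 154000 nM. Compound 3 also stops at a limit in this assay, > 156000 nM. Because all three sit at limits, (the limit of > 154000 nM in this assay, at which 1 of the 3 values shown sits), the limit of > 156000 nM in this assay, at which 1 of the 3 values shown sits, and (the limit of > 157000 nM in this assay, at which 1 of the 3 values shown sits), none of the steps among them can be read: a step that the two limits leave unreadable from compound 2 to compound 1, a step that the two limits leave unreadable from compound 1 to compound 3 and a step that the two limits leave unreadable from compound 2 to compound 3.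

The change from compound 3 to compound 4 is hydrogen in place of methoxy on an aromatic carbon. The same kind of change was made from compound 2 to compound 1, (hydrogen in place of methoxy on an aromatic carbon), but there the place is also meta to a hydroxy group, so the surroundings are not identical. The cores of compound 2 and compound 3 differ by hydrogen in place of hydroxy on an aromatic carbon.

Since every measured value in this assay is a limit, the step from compound 3 to compound 4 is expected to be small, a step that the limit leaves unreadable from compound 3 to compound 4, and compound 4 is expected to land near 157000 nM, most likely again reported only as a limit, between 90000 nM and 300000 nM.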

Compound 4, half-maximal inhibitory concentration: > 210000 nM
Compound 4: a limit, no number; the forecaster's own chance of this, stated with the estimate: 85%; middle value at least 1.3-fold (0.12 log units) from the limit.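

In this assay compound 4 also gives only a limit, > 210000 nM. For the compounds shown here, compound 1, compound 2 and compound 3 stop at limits too, so no step from any of them to compound 4 can be read. The compounds shown leave open whether the different aryl groups on the saturated ring carbon change the result in this assay at all, and how far.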